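A few compounds are considered here, and "the series" means these few. Any claim that something is new, unique, unknown or untested is made for them only; others in the source may bear on it.

In a functional assay on HeLa cells (Homo sapiens) for inhibition (on this read-out higher numbers stand for weaker inhibition and lower numbers for stronger inhibition), three compounds sharing one core have been measured. Compound 1 `COC(=O)C(C(=O)OC)C1CC(=O)C=CC12OCC(=O)N2Cc1ccc(C)cc1` gives 410 nM, compound 2 `COC(=O)C(C(=O)OC)C1CC(=O)C=CC12OCC(=O)N2Cc1ccc(Cl)cc1` gives 180 nM, and compound 3 `COC(=O)C(C(=O)OC)C1CC(=O)C=CC12OCC(=O)N2Cc1ccc(Br)cc1` gives 1060 nM. Compound 3 therefore has the highest number and is the weakest inhibitor of the three. The next compound, compound 4 `COC(=O)C(C(=O)OC)C1CC(=O)C=CC12OCC(=O)N2Cc1cccc(Cl)c1`, changes one group of compound 3: 3-chlorophenyl in place of 4-bromophenyl on a saturated chain carbon bound to an amide-type nitrogen in a ring. Bromo is gone and chloro takes its place, as in compound 2, so the most relevant measurement is the modest step of a 5.9-fold higher number from compound 2 to compound 3 (0.77 log units; beyond the scatter), where bromo replaced chloro. The step of a 2.6-fold higher number from compound 1 to compound 3 (0.41 log units; beyond the scatter), also modest, shows that bromo gave a higher number than methyl as well. Both suggest that losing bromo may lower the number. However, no measured compound carries a 3-chlorophenyl group, so the full gain seen with compound 2 cannot be assumed. The estimated change is a modest drop, a 2.7-fold lower number from compound 3 to compound 4 (0.42 log units; beyond the scatter). For compound 4 the expected value is 400 nM, with an estimated range from 130 nM to 1200 nM.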

Compound 4, half-maximal inhibitory concentration: 340 nM
Compound 4: middle estimate off by 1.2-fold (0.07 log units), on the high side; the range from low to high includes it.
By their numbers in this assay, from the lowest: compounds 2, 4 and 1 (each within the scatter of the next, the first and the last beyond it); then compound 3.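

In this assay the change from 4-bromophenyl to 3-chlorophenyl on this saturated chain carbon gives a 3.1-fold lower number from compound 3 to compound 4 (0.49 log units; beyond the scatter) and shows that the benzyl group can carry chlorine in a second arrangement without returning to the number of compound 3. Against 4-chlorophenyl the result is a 1.9-fold higher number from compound 2 to compound 4 (0.28 log units; within the scatter) and against 4-methylphenyl it is a 1.2-fold lower number from compound 1 to compound 4 (0.08 log units; within the scatter) so neither change separates compound 4 from its partner here. Nothing measured on these compounds explains these differences.

Because this step swaps the halogen and its arrangement together, the compounds shown cannot tell which of the two matters, and 3-bromophenyl would be the group to separate them. On these data alone, how a more different group at this place, such as 4-aminophenyl or 4-carboxyphenyl, would read also stays open.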